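Leaving quinolin-4-yl behind: from compound 2 to compound 3

This account rests on a few compounds, and the source may have more. Where it says the series, first, only, none or still open, it means among the compounds named here.

In a functional assay on HCT-15 cells (Homo sapiens) for antiproliferative activity (a lower number here means a stronger inhibitor, a higher number a weaker inhibitor), compound 1 (`COc1ccc(S(=O)(=O)Oc2ccccc2NC(=O)c2ccncc2)cc1`) gives 89 nM.

Compound 2 (`COc1ccc(S(=O)(=O)Oc2ccccc2NC(=O)c2ccnc3ccccc23)cc1`) gives > 10000 nM, which is a limit of the assay and not a number.

So compound 2 stands at the weak end of the two values known so far. Compound 3 (`COc1ccc(S(=O)(=O)Oc2ccccc2NC(=O)c2ccc(N(C)C)cc2)cc1`) keeps the shared core but carries 4-(dimethylamino)phenyl in place of quinolin-4-yl on a carbonyl carbon.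

Among the measured compounds shown here, only one measured step bears on this change, and it involves the same place and the group that now leaves. That step, an at least 110-fold higher number from compound 1 to compound 2 (2.05 log units; beyond the scatter), is large and beyond the scatter. Removing quinolin-4-yl may therefore undo much of that loss in this assay, although the entering group is not the pyridin-4-yl of compound 1, so the full recovery cannot be assumed. A large move toward a lower number is expected.

The estimated change is an at least 16-fold lower number from compound 2 to compound 3 (1.22 log units; beyond the scatter).

Compound 3 is expected at about 600 nM, with an estimated range from 60 nM to 6000 nM.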

Compound 3, half-maximal inhibitory concentration: > 10000 nM
Compound 3 was reported as a limit; the forecaster's own chance of this, stated with the estimate: 15%; middle value at least 16-fold (1.22 log units) away from the limit.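

Compound 3, like compound 2, ends at a limit of this assay, so the step between these two cannot be read and neither can be placed ahead of the other: the limit of > 10000 nM in this assay, at which 2 of the 3 values shown sit.

The readable comparison is with compound 1. Putting 4-(dimethylamino)phenyl in place of pyridin-4-yl on the carbonyl carbon gives an at least 110-fold higher number from compound 1 to compound 3 (2.05 log units; beyond the scatter), so the loss is not tied to quinolin-4-yl alone, and of the three groups at this place only the pyridin-4-yl of compound 1 keeps a measurable value, 89 nM.

From the compounds shown here alone, what remains open is how much of the activity of compound 1 depends on the ring nitrogen of pyridin-4-yl, a question that a plain phenyl ring or a pyridin-3-yl group on the same carbonyl carbon would address directly. The compounds shown also cannot tell how far compound 2 and compound 3 lie past their limits, or whether they differ from each other at all.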